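From (3,4-dimethylphenyl)amino to pyrrolidin-1-yl on a shared core

The compounds below may be only part of what the source reports. "The series", "measured", "known", "first", "only" and "open" are said of these compounds alone.

Compound 1 `O=C1C(Nc2ccc(I)cc2)=CC(=O)c2c1nc1n2[C@H]2OC[C@@H](O)[C@H]2OC1` gives 3890 nM
Compound 2 `O=C1C(Nc2ccccc2F)=CC(=O)c2c1nc1n2[C@H]2OC[C@@H](O)[C@H]2OC1` gives only a limit, > 4000 nM
Compound 3 `Cc1ccc(NC2=CC(=O)c3c(nc4n3[C@H]3OC[C@@H](O)[C@H]3OC4)C2=O)cc1C` gives 4950 nM

In a functional assay on MCF7 cells (Homo sapiens) for inhibition, read by sulforhodamine B assay (on this read-out lower numbers stand for stronger inhibition and higher numbers for weaker inhibition), compound 3 stands within the scatter of compound 1 (a 1.3-fold higher number from compound 1 to compound 3 (0.10 log units; within the scatter)). Compound 4 `O=C1C(N2CCCC2)=CC(=O)c2c1nc1n2[C@H]2OC[C@@H](O)[C@H]2OC1` carries pyrrolidin-1-yl in place of (3,4-dimethylphenyl)amino on a double-bonded ring carbon. The measured steps only exchange one phenyl group on an amine nitrogen for another (an at least 1.0-fold higher number from compound 1 to compound 2 (0.01 log units; that floor lies within the scatter); a step that the limit leaves unreadable from compound 2 to compound 3). None removes the phenyl ring, so they bear on this change only loosely, and no step beyond the scatter is expected, with wide uncertainty. a 1.0-fold higher number from compound 3 to compound 4 (0.00 log units; within the scatter) is the step expected here. Compound 4 is estimated at 5000 nM (expected range 1800 nM to 14000 nM).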

Compound 4, half-maximal inhibitory concentration: > 16000 nM
Compound 4 was reported as a limit; the forecaster's own chance of this, stated with the estimate: 35%; middle value at least 3.2-fold (0.50 log units) from the limit.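

On this double-bonded ring carbon, the earlier exchanges of one phenyl group for another gave no readable step beyond the scatter, whereas removing the phenyl ring does: in this assay there is an at least 3.2-fold higher number from compound 3 to compound 4 (0.50 log units; beyond the scatter) and an at least 4.1-fold higher number from compound 1 to compound 4 (0.61 log units; beyond the scatter). The value of compound 4, > 16000 nM, is a limit, so both steps give only a floor. The step between compound 2 and compound 4 cannot be read.

The compounds shown leave open whether the difference goes with the aromatic ring or with the amine hydrogen, as both leave together. A cyclohexylamino group or an N-methyl-N-phenylamino group on this carbon would separate the two.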